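Repeating a Fluoro-for-Hydrogen Change on a Second Core

A few compounds are considered here, and "the series" means these few. Any claim that something is new, unique, unknown or untested is made for them only; others in the source may bear on it.

Compound 1 `O=S(=O)(Nc1ccccc1)c1ccc(Br)cc1` and compound 2 `O=S(=O)(Nc1ccc(F)cc1)c1ccc(Br)cc1` share one core and differ only by fluoro in place of hydrogen on an aromatic carbon. In an ADME assay, compound 1 gives 8.5, and compound 2 gives 8.38, so the change made a number 0.12 log units lower from compound 1 to compound 2 (within the scatter).

Compound 3 `Cc1ccc(NS(=O)(=O)c2ccccc2)cc1` is built on a different core; the difference between the two cores is not broken down here. In this assay compound 3 gives 9.34, which stands beyond the scatter of both compound 1 and compound 2.

Compound 4 `Cc1ccc(NS(=O)(=O)c2ccc(F)cc2)cc1` has not yet been measured. It differs from compound 3 by fluoro in place of hydrogen on an aromatic carbon, the same change that turned compound 1 into compound 2, made at a place described in the same words. Because that earlier change made a number 0.12 log units lower from compound 1 to compound 2 (within the scatter), the step from compound 3 to compound 4 is expected to be small as well, about a number 0.12 log units lower from compound 3 to compound 4 (within the scatter). Compound 4 is therefore estimated at 9.22, most likely between 8.95 and 9.5, with the core of compound 3 setting the level.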

Compound 4, acid dissociation constant: 9.23
Compound 4: the middle estimate sits 0.01 log units below what was measured, within the range that was stated.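

In this assay, fluoro in place of hydrogen on an aromatic carbon gives a number 0.11 log units lower from compound 3 to compound 4 (within the scatter). Set beside the same change on the other core, the two steps agree closely: the same change on two cores in this assay, a number 0.12 log units lower (within the scatter) from compound 1 to compound 2 and a number 0.11 log units lower (within the scatter) from compound 3 to compound 4, 0.01 log units apart, within the scatter of two such steps.
Going by these compounds alone, in this series, then, the change carries from one core to the other as a step too small to tell apart from the ordinary spread of repeat measurements, but two cores are only two examples, and neither step shows that the fluoro group moves the number at all.

The compounds shown test only fluoro as the entering group, so it remains open whether an amine, a methoxy group or a carboxylic acid in that place would give a step beyond the scatter. Going by these compounds, it also remains open whether fluoro would give an equally small step on a third core, or at another place on these two.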